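Replacing cyano in compound 2: notes on compound 3

The compounds below may be only part of what the source reports. "The series", "measured", "known", "first", "only" and "open" are said of these compounds alone.

- Compound 1 `[O-][S+]1CCCC[C@@H]1c1cccnc1` gives > 30000 nM as a limit
- Compound 2 `N#C[C@]1(c2cccnc2)CCCC[S+]1[O-]` gives > 30000 nM as a limit

In a functional assay (aorta) for inhibition, with Rattus norvegicus as the target (a higher number here means a weaker inhibitor, a lower number a stronger inhibitor), compound 2 stands at > 30000 nM which is a limit and not a number. Going by the values given here, the series so far offers only the limit of > 30000 nM in this assay, at which 2 of the 2 values shown sit, and no measured step.

Compound 3 `COC(=N)[C@]1(c2cccnc2)CCCC[S+]1[O-]` changes the group on a saturated ring carbon next to the ring sulfur a group of 4 heavy atoms (2 carbon, 1 nitrogen, 1 oxygen; no ring) in place of a group of 2 heavy atoms (1 carbon, 1 nitrogen; no ring), on a saturated ring carbon and nothing else.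

In this assay the expected at least 1.5-fold lower number from compound 2 to compound 3 (0.17 log units; that floor lies within the scatter) is a modest move toward stronger inhibition, and another limit is quite possible. The estimate for compound 3 is 20000 nM with an expected range from 3000 nM to 60000 nM as its ends.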

Compound 3, concentration for 90% inhibition: > 30000 nM
Compound 3: no number, only a limit; the forecaster's own chance of this, stated with the estimate: 55%; middle value at least 1.5-fold (0.17 log units) away from the limit.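

Going by these compounds alone, compound 2 and compound 3 both stand only as limits, so no step between them can be read in this assay: the limit of > 30000 nM in this assay, at which 3 of the 3 values shown sit.

The compounds shown leave open whether any group on this saturated ring carbon gives a measurable number in this assay.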